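The compounds below may be only part of what the source reports. "The series", "measured", "known", "first", "only" and "open" are said of these compounds alone.

Measured so far:
In an ADME assay on HEK293 cells (Homo sapiens) for cytotoxicity, read by reporter gene assay and resazurin assay, with a stated time of 48 h (on this read-out lower numbers stand for higher toxicity in this test and higher numbers for lower toxicity in this test), compound 1 `O=C(Nc1cccc(Cl)c1)c1cccc(Br)c1` gives 51000 nM.
Compound 2 `O=C(Nc1ccccc1)c1cc(Br)cc(Br)c1` gives > 100000 nM, which is a limit of the assay and not a number.

Compound 2 therefore stands at the limit of > 100000 nM in this assay, at which 1 of the 2 values shown sits. Compound 3 `O=C(Nc1cccc(Cl)c1)c1cc(Br)cc(Br)c1` differs from compound 2 by chloro in place of hydrogen on an aromatic carbon. Among the measured compounds shown here, no measured pair covers this change, so the size of the step in this assay is open; a small step toward higher toxicity, or none beyond the scatter, is expected, compound 1 giving 51000 nM with a chloro present. Compound 3 is estimated at 65000 nM, within 25000 nM to 150000 nM. This estimate would mean an expected at least 1.5-fold lower number from compound 2 to compound 3 (0.18 log units; that floor lies within the scatter).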

Compound 3, half-maximal cytotoxic concentration: 53000 nM
Estimate against measurement, compound 3: 1.2-fold (0.09 log units) above; measured number inside the range.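

Compound 2 gives > 100000 nM in this assay, which is a limit of the assay and not a number. Chloro in place of hydrogen on an aromatic carbon therefore has only a floor for its size: an at least 1.8-fold lower number from compound 2 to compound 3 (0.27 log units; that floor lies within the scatter). With chloro present, adding bromo gives a 1.0-fold higher number from compound 1 to compound 3 (0.02 log units; within the scatter), so this added bromo leaves the read-out unresolved from that of compound 1.

On these data alone, whether the chloro step truly exceeds the scatter remains open. So does the outcome of an amine or a carboxylic acid in place of chloro at this position.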